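This account rests on a few compounds, and the source may have more. Where it says the series, first, only, none or still open, it means among the compounds named here.

Measured compounds in a toxicity assay on THP-1 cells (Homo sapiens) for inhibition; a lower number here means that less compound is tolerated, a higher number that more compound is tolerated:
Compound 1 `COc1ccc(-c2cnc(NC(=O)c3ccc([N+](=O)[O-])cc3)n2C)cc1` reaches only a limit in this assay, > 100000 nM.
Compound 2 `COc1ccc(-c2cnc(NC(=O)c3ccc(O)cc3)n2C)cc1` likewise reaches only a limit, > 100000 nM.
Compound 3 `Cn1c(-c2ccccc2[N+](=O)[O-])cnc1NC(=O)c1ccc(F)cc1` gives 31000 nM.

Compound 2 therefore stands at the limit of this assay, a limit at which most of the values at hand sit (the limit of > 100000 nM in this assay, at which 2 of the 3 values shown sit). The step from compound 1 to compound 2, a step that the two limits leave unreadable from compound 1 to compound 2, is left unreadable by the two limits. Compound 4 `COc1ccc(-c2cnc(NC(=O)c3ncc[nH]3)n2C)cc1` carries 1H-imidazol-2-yl in place of 4-hydroxyphenyl on a carbonyl carbon. For the measured compounds named here, no measured step touches this carbonyl position, and compound 3, the only compound with a read number, differs from compound 2 in more than one place, so nothing sets a direction. For compound 4 the expected step is therefore a number no higher from compound 2 to compound 4 (the limit leaves the size open), not beyond the scatter, with the limit the most likely outcome. Compound 4 is estimated at 100000 nM, within a range from 30000 nM to 300000 nM.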

Compound 4, half-maximal cytotoxic concentration: > 100000 nM
Compound 4: a limit, no number; the forecaster's own chance of this, stated with the estimate: 70%; the middle value lies on the limit itself.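

Compound 2 and compound 4 both reach only a limit in this assay, so the step between them cannot be read. The compounds shown leave open whether any group on this carbonyl carbon would give a readable number in this assay.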